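The source may report more compounds than this note shows. Statements on the series, on what has been measured and on what is new or still open speak of the compounds shown alone.

Measured in a functional assay on A549 cells (Homo sapiens) for cytotoxicity, read by MTT assay, with a stated time of 72 h; on this read-out higher numbers stand for weaker inhibition and lower numbers for stronger inhibition:
Compound 1 (`COC(=O)c1sc2cc(OC)ccc2c1Nc1cc(OC)c(OC)c(OC)c1`): 8.5 nM
Compound 2 (`CCOC(=O)c1sc2cccc(C)c2c1Nc1cc(OC)c(OC)c(OC)c1`): 6250 nM

Compound 1 has the lower of these two numbers, so it is the stronger inhibitor, and its gap to compound 2 lies well beyond the usual scatter. These two compounds differ in more than one place, so that gap cannot be pinned on any single group.

Compound 3 (`COC(=O)c1sc2ccccc2c1Nc1cc(OC)c(OC)c(OC)c1`) has not yet been measured. It keeps the core of compound 1 and makes one change: hydrogen in place of methoxy on an aromatic carbon. Among the measured compounds shown here, no pair of measured compounds differs in just one place, so the evidence is thin. For the measured compounds named here, the only hint comes from compound 2, which also lacks that methoxy and gives 6250 nM while differing elsewhere too.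

A rise in the number beyond the scatter, meaning weaker inhibition, is therefore expected in this assay (an estimated 35-fold higher number from compound 1 to compound 3 (1.55 log units; beyond the scatter)). For compound 3 the estimated value is 300 nM with an expected range from 40 nM to 3000 nM as the likely span.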

Compound 3, half-maximal inhibitory concentration: 2850 nM
Compound 3: middle estimate off by 9.5-fold (0.98 log units), on the low side, and the stated range covers the measured number.
By their numbers in this assay, from the lowest: compound 1; then compound 3; then compound 2.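

In this assay, replacing the methoxy group with hydrogen on this aromatic carbon, part of a fused system of two rings, gives a 340-fold higher number from compound 1 to compound 3 (2.53 log units; beyond the scatter), a large step well beyond the usual scatter. Among the compounds shown here, the gap between compound 1 and compound 2 could not be tied to any one group, but here only this group changes, so the loss of inhibition can be traced to the methoxy at this place. Two heavy atoms at this one carbon therefore account for much of the strength of compound 1 in this test, although nothing measured here explains how the methoxy group produces this effect.

The compounds shown leave open whether methoxy is specifically required or whether another group at the same carbon, such as a hydroxyl, a fluorine, an amine or a longer ethoxy chain, could restore the inhibition. They also leave open whether a methoxy group at the other carbons of this six-membered ring would give similar strength, since none of the compounds shown tests this in a single change.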